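Swapping allyl for 4-fluorophenyl on a weak compound

This account rests on a few compounds, and the source may have more. Where it says the series, first, only, none or still open, it means among the compounds named here.

Measured in a functional assay on MCF7 cells (Homo sapiens) for antiproliferative activity, read by MTT assay, with a stated time of 72 h; a lower number here means a stronger inhibitor, a higher number a weaker inhibitor:
- compound 1 `C=CC/N=C1\S/C(=C\c2ccc(OC)cc2)C(=O)N1C`: > 100000 nM (a limit of the assay, not a number)
- compound 2 `COc1ccc(/C=C2/CN(C)/C(=N/c3ccc(Br)cc3)S2)cc1`: 7400 nM
- compound 3 `COc1ccc(/C=C2\S/C(=N\c3cc(C(F)(F)F)cc(C(F)(F)F)c3)N(C)C2=O)cc1`: 77800 nM

Compound 1 stands at the limit of > 100000 nM in this assay, at which 1 of the 3 values shown sits. Its true value is therefore unknown, and it marks the weak end of this small set.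

Compound 4 `COc1ccc(/C=C2\S/C(=N\c3ccc(F)cc3)N(C)C2=O)cc1` has not yet been measured. It carries 4-fluorophenyl in place of allyl on a double-bonded nitrogen, a change counted as 4-fluorophenyl in place of allyl on a double-bonded nitrogen.

For the measured compounds named here, no pair of measured compounds shows this change directly, so the expectation rests on loose comparisons. Compound 2 and compound 3 both have an aromatic ring on that nitrogen and both give numbers. Compound 2 gives 7400 nM, although its core differs from that of compound 4. Compound 3 gives 77800 nM and is the closer comparison.

A modest gain in this assay is therefore expected, shown as the estimated at least 3.3-fold lower number from compound 1 to compound 4 (0.52 log units; beyond the scatter). The estimate for compound 4 is 30000 nM, with an expected range of 8000 nM to 100000 nM.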

Compound 4, half-maximal inhibitory concentration: 66500 nM
The estimate for compound 4 lay 2.2-fold (0.35 log units) below the measured number; measured number inside the range.
By their numbers in this assay, from the lowest: compound 2; then compounds 4 and 3 (each within the scatter of the next). At a limit, above all of these: compound 1.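

In this assay, for the compounds shown here, compound 4, which carries 4-fluorophenyl in place of allyl on the double-bonded nitrogen, gives a measurable 66500 nM, and this gives the first direct pair for a change at this position. Compound 1 stands at > 100000 nM, which is a limit of the assay and not a number. The change therefore reads as an at least 1.5-fold lower number from compound 1 to compound 4 (0.17 log units; that floor lies within the scatter), and its true size stays unknown because of this limit: the limit of > 100000 nM in this assay, at which 1 of the 4 values shown sits.

The compounds shown leave open whether the fluorine or the aromatic ring itself goes with the measurable value, which a plain phenyl ring on the same nitrogen could help to separate. They also leave open how a saturated cyclohexyl ring or a longer chain such as butyl would read in this position.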